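The source may hold more compounds than are shown below. What is called first, only, known or untested is meant among the compounds shown, and "the series" means these compounds.

Measured so far in an ADME assay on TZM cells (Homo sapiens) for cytotoxicity, read by WST assay, with a stated time of 2 days; on this read-out lower numbers stand for higher toxicity in this test and higher numbers for lower toxicity in this test:
- Compound 1 `COc1ccc(CN(C)c2nc(C(C)c3c(Cl)cccc3Cl)c(C)c(=O)[nH]2)cc1`: > 100000 nM, a limit of the assay and not a number
- Compound 2 `Cc1c(C(C)c2c(F)cccc2F)nc(N(C)Cc2ccc(N3CCN(C)CC3)cc2)[nH]c1=O`: 26200 nM

For the measured compounds named here, compound 2 carries the only actual number in this small series, at 26200 nM. The other reading is a limit, so there is no numerical scale to place compound 2 on. Going by the values given here, no step between measured compounds that differ in one place is available.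

Compound 3 `COc1ccc(CN(C)c2nc(C(C)c3c(F)cccc3F)c(C)c(=O)[nH]2)cc1` is compound 2 with methoxy in place of 4-methylpiperazin-1-yl on an aromatic carbon of a six-membered aromatic ring of carbon only, para to a large group: methoxy in place of 4-methylpiperazin-1-yl on an aromatic carbon.

Among the compounds with values here, the only guide to this change is compound 1, which also bears a methoxy and reads > 100000 nM, again a limit. In this assay, a rise in the read-out beyond the usual scatter is therefore expected, toward lower toxicity in this test. The expected size is a 3.2-fold higher number from compound 2 to compound 3 (0.51 log units; beyond the scatter). A reading reported only as a limit is quite possible.

For compound 3 the estimated value is 85000 nM, with an expected range of 40000 nM to 150000 nM.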

Compound 3, half-maximal cytotoxic concentration: 88800 nM
For compound 3 the middle estimate is 1.0-fold (0.02 log units) below the measured one, and the stated range covers the measured number.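

In this assay, the aromatic carbon para to a large group now has a real number on both sides of a one-place change: methoxy in place of 4-methylpiperazin-1-yl gives a 3.4-fold higher number from compound 2 to compound 3 (0.53 log units; beyond the scatter), so with 2,6-difluorophenyl held constant, the 4-methylpiperazin-1-yl compound shows the higher toxicity in this test. Compound 1 reads > 100000 nM, a limit of the assay and not a number. The change to 2,6-difluorophenyl in place of 2,6-dichlorophenyl gives an at least 1.1-fold lower number from compound 1 to compound 3 (0.05 log units; that floor lies within the scatter), and as this step starts from a limit it sets no order between the two groups: the limit of > 100000 nM in this assay, at which 1 of the 3 values shown sits.

Still open, from the compounds shown here alone, is whether the difference follows the whole ring of 4-methylpiperazin-1-yl or only its nitrogen atoms, and a morpholin-4-yl or a dimethylamino group on the same aromatic carbon would bear on that. Going by these compounds, the methoxy step also rests on a single pair, so whether it holds with 2,6-dichlorophenyl in the 2,6-difluorophenyl place remains unknown.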